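Second chloro added to compound 1: a forecast

This account rests on a few compounds, and the source may have more. Where it says the series, first, only, none or still open, it means among the compounds named here.

Measured compounds:
compound 1 `ClCc1ccc(Cn2cnc3c(Cl)ncnc32)cc1` — 30900 nM
compound 2 `ClCc1ccc(Cn2cnc3nc(Cl)nc(Cl)c32)cc1` — 5120 nM
compound 3 `ClCc1ccccc1Cn1cnc2ncnc(Cl)c21` — 18600 nM

In a functional assay on SK-MEL-28 cells (Homo sapiens) for cytotoxicity, read by sulforhodamine B assay, with a stated time of 48 h (on this read-out lower numbers stand for stronger inhibition of growth and higher numbers for weaker inhibition of growth), compound 1 gives 30900 nM, the highest number among the three measured compounds. Compound 3 gives 18600 nM, which lies within the scatter of compound 1, so no order between them can be claimed. Compound 2, which carries two chloro groups on its core, gives 5120 nM, a number beyond the scatter below that of compound 1.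

Compound 4 `ClCc1ccc(Cn2cnc3c(Cl)nc(Cl)nc32)cc1` differs from compound 1 by a single change: chloro in place of hydrogen on an aromatic carbon. Compound 4 thus carries two chloro groups on its core, as compound 2 does, although the two compounds are not otherwise identical. Among the measured compounds shown here, since compound 2 shows a lower number than compound 1, compound 4 is expected to show a step of a 4.4-fold lower number from compound 1 to compound 4 (0.64 log units; beyond the scatter) toward a lower number, beyond the scatter, though its size is uncertain because only one dichloro compound is known. Compound 4 is therefore estimated at 7000 nM, with a range from 2500 nM to 20000 nM.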

Compound 4, concentration for total growth inhibition: 6920 nM
For compound 4 the middle estimate is 1.0-fold (0.00 log units) above the measured one; the measured number falls inside the stated range.
By their numbers in this assay, from the lowest: compounds 2 and 4 (each within the scatter of the next); then compounds 3 and 1 (each within the scatter of the next).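

In this assay chloro in place of hydrogen on an aromatic carbon, between two ring nitrogen atoms, gives a 4.5-fold lower number from compound 1 to compound 4 (0.65 log units; beyond the scatter) as a modest step with nothing else on the molecule altered. Among the compounds shown here, this is the first pair here that differs in one place, so it shows that this position of the core of compound 1 responds to a single added chloro, which the earlier compounds, differing in more than one place, could not show. No measurement here accounts for the step.

The compounds shown leave open whether an amine or a methoxy group at this position would change the number as chloro does. They also leave open whether the same chloro on compound 3 would give a step of similar size.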